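The compounds below may be only part of what the source reports. "The series", "measured", "known", "first", "only" and "open" are said of these compounds alone.

Measured compounds:
- compound 1, `COc1ccc(Cn2c(-c3ccccc3)c(-c3ccccc3)c3c(=N)n(C4CCOCC4)cnc32)cc1`: "nd" (no result reported)
- compound 2, `COc1ccc(-c2c(-c3ccc(OC)cc3)n(Cc3ccccc3)c3ncn(CCCO)c(=N)c23)cc1`: > 1000 10^-6 cm/s

The study reports an ADME assay for permeability, using PAMPA, with a stated time of 30 min, at pH 7.4 (a higher number here means that the compound crosses the layer faster, a lower number that the compound crosses the layer more slowly), for two compounds of a shared core. For compound 1, `COc1ccc(Cn2c(-c3ccccc3)c(-c3ccccc3)c3c(=N)n(C4CCOCC4)cnc32)cc1`, no result is given in this assay: the entry reads "nd" (no result reported). In this assay compound 2, `COc1ccc(-c2c(-c3ccc(OC)cc3)n(Cc3ccccc3)c3ncn(CCCO)c(=N)c23)cc1`, gives > 1000 10^-6 cm/s, which is a limit of the assay and not a number. So compound 2 stands at the upper edge of what this assay can report, as the record shows in the limit of > 1000 10^-6 cm/s in this assay, at which 1 of the 2 values shown sits, and no other compound in the set offers a number to set beside it.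

The step taken here leads from compound 2 to compound 3, `COc1ccc(-c2c(-c3ccc(OC)cc3)n(Cc3ccccc3)c3ncn(CC4CCOC4)c(=N)c23)cc1`, which has not yet been measured in this assay. The change is oxolan-3-yl in place of 2-hydroxyethyl on a saturated chain carbon bound to an aromatic nitrogen. With compound 2 already at the limit, the expected step of a number no higher from compound 2 to compound 3 (the limit leaves the size open) cannot be told apart from the scatter, and the most likely outcome is that compound 3 is again reported as a limit. Compound 3 is therefore expected to give about 1000 10^-6 cm/s in this assay, within a range from 500 10^-6 cm/s to 1500 10^-6 cm/s.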

Compound 3, apparent permeability: > 1000 10^-6 cm/s
Compound 3 was reported as a limit; the forecaster's own chance of this, stated with the estimate: 70%; the middle value sits exactly at the limit.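

In this assay compound 3 gives > 1000 10^-6 cm/s, which is a limit of the assay and not a number. Among these compounds, compound 2 stands at a limit as well, and no step between compound 2 and compound 3 can be read. The compounds shown leave open what the apparent permeability of either compound is, and whether the two differ at all.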